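A few compounds are considered here, and "the series" means these few. Any claim that something is new, unique, unknown or untested is made for them only; others in the source may bear on it.

Measured so far in an ADME assay on EC17 cells (Homo sapiens) for cytotoxicity, read by trypan blue exclusion; a higher number here means a weaker inhibitor, a lower number a stronger inhibitor:
Compound 1 `C=C(CC/C=C(\C)CCC=C(C)C)C(O)Cc1c(O)cc(C)c(C=O)c1O` gives > 80000 nM, which is a limit of the assay and not a number.
Compound 2 `C=C(CC[C@@]1(C)[C@H](C)CCC(=O)[C@@H]1C)[C@H](O)Cc1c(O)cc(C)c(C=O)c1O` gives > 77000 nM, again a limit of the assay and not a number.
Compound 3 `C=C(CC[C@H]1[C@@H](C)CCCC1(C)C)C(O)Cc1c(OC)cc(C)c(C=O)c1O` gives 18000 nM.

Within the data shown here, compound 3 therefore stands as the only compound with an actual number in this assay; the two other values are limits and cannot be ranked against it. Among the measured compounds shown here, no pair of measured compounds differs in just one place, so no single measured step is available for comparison.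

Compound 4 `C=C(CC[C@H]1[C@@H](C)CCCC1(C)C)C(O)Cc1c(O)cc(C)c(C=O)c1O` has not yet been measured. It differs from compound 3 in one place: hydrogen in place of methyl on an oxygen on an aromatic ring. Compound 4 shares this hydroxy with compound 2, which in this assay reaches only (the limit of > 77000 nM in this assay, at which 1 of the 3 values shown sits). Compound 1, carrying the same hydroxy, likewise reaches only (the limit of > 80000 nM in this assay, at which 1 of the 3 values shown sits). For the measured compounds named here, compound 3, with the methoxy, is the one compound that returns a number.

On that basis compound 4 is expected to be a weaker inhibitor than compound 3 in this assay, with an estimated step of a 2.5-fold higher number from compound 3 to compound 4 (0.40 log units; beyond the scatter), larger than the usual scatter. The estimate for compound 4 is 45000 nM, with a range from 15000 nM to 110000 nM, and a real chance that the assay reports only a limit.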

Compound 4, half-maximal inhibitory concentration: 46000 nM
Compound 4: the middle estimate sits 1.0-fold (0.01 log units) below what was measured; the range from low to high includes it.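

With the rest of the molecule held constant, the change from methoxy to hydroxy on the aromatic ring now has a measured size in this assay: a 2.6-fold higher number from compound 3 to compound 4 (0.41 log units; beyond the scatter). Compound 4 carries the hydroxy and still returns a number, so in this series the hydroxy alone does not put a compound at the limit of the assay. Among the compounds with this hydroxy, exchanging the side chain gives an at least 1.7-fold lower number from compound 1 to compound 4 (0.24 log units; that floor lies within the scatter), and this step rests on a limit and not on a number: the limit of > 80000 nM in this assay, at which 1 of the 4 values shown sits.

From the compounds shown here alone, it remains open whether the change from methoxy to hydroxy has the same size on the side chains of compound 1 and compound 2. The compounds shown also leave open what a longer ether such as ethoxy, or an amine in place of this oxygen, would do to the number in this assay.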